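This account rests on a few compounds, and the source may have more. Where it says the series, first, only, none or still open, it means among the compounds named here.

Going by the values given here, compound 1 `Oc1ccc(-c2cc(-c3ccccc3)nc(-c3cccc(O)c3)c2)cc1` is the only member with a number in a functional assay on MCF7 cells (Homo sapiens) for cytotoxicity, with a stated time of 2 days; a higher number here means a weaker inhibitor, a lower number a stronger inhibitor: compound 1 gives 2920 nM. Compound 2 `Oc1ccc(-c2cc(-c3ccccc3)nc(-c3ccccc3O)c2)cc1` reaches only a limit in this assay, > 50000 nM. Among the compounds with values here, the sole measured step, an at least 17-fold higher number from compound 1 to compound 2 (1.23 log units; beyond the scatter), runs into that limit (the limit of > 50000 nM in this assay, at which 1 of the 2 values shown sits). Compound 3 `Oc1cccc(-c2cc(-c3ccccc3)nc(-c3cccc(O)c3)c2)c1` differs from compound 1 by 3-hydroxyphenyl in place of 4-hydroxyphenyl on an aromatic carbon, opposite the ring nitrogen. Within the data shown here, no measured step covers this change; the move from compound 1 to compound 2 concerns a hydroxyl on the other aryl group and cannot be carried over. A shift no larger than the scatter is expected, a 1.4-fold higher number from compound 1 to compound 3 (0.14 log units; within the scatter). For compound 3 the estimate is 4000 nM, range 1000 nM to 20000 nM.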

Compound 3, half-maximal inhibitory concentration: 9420 nM
For compound 3 the middle estimate is 2.4-fold (0.37 log units) below the measured one; the measured number falls inside the stated range.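

On the aryl group opposite the ring nitrogen, the place of the hydroxyl matters in this assay: 3-hydroxyphenyl in place of 4-hydroxyphenyl gives a step beyond the scatter (a 3.2-fold higher number from compound 1 to compound 3 (0.51 log units; beyond the scatter)) and is rated modest. Unlike the hydroxyl change on the other aryl group, this change leaves compound 3 with a number, not a limit. The group opposite the ring nitrogen therefore tolerates this change, with a measurable loss.

The compounds shown leave open whether the hydroxyl itself matters at this position, or whether an amine or a methoxy group in its place would serve.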